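This account rests on a few compounds, and the source may have more. Where it says the series, first, only, none or still open, it means among the compounds named here.

Three compounds have been measured so far in a functional assay on MKN-45 cells (Homo sapiens) for antiproliferative activity, read by MTT assay, with a stated time of 72 h (a higher number here means a weaker inhibitor, a lower number a stronger inhibitor), as follows

Compound 1 `COc1cc2c(Oc3ccc(Nc4nccc5[nH]cc(-c6ccc(F)cc6)c(=O)c45)cc3F)ccnc2cc1OCCO` gives 1600 nM
Compound 2 `CC(C)(O)COc1ccc2c(Oc3ccc(Nc4nccc5[nH]cc(-c6ccc(F)cc6)c(=O)c45)cc3F)ccnc2c1` gives 2700 nM
Compound 3 `COCCOc1cc2nccc(Oc3ccc(Nc4nccc5[nH]cc(-c6ccc(F)cc6)c(=O)c45)cc3F)c2cc1OC` gives 3100 nM

Compound 2 lies within the usual scatter of both compound 1 and compound 3, so no order can be drawn among the three. Compound 4 `COC(C)(C)COc1ccc2c(Oc3ccc(Nc4nccc5[nH]cc(-c6ccc(F)cc6)c(=O)c45)cc3F)ccnc2c1` has not yet been measured, and it departs from compound 2 by a single change (methyl in place of hydrogen on an oxygen on a saturated carbon). This is methyl in place of hydrogen on an oxygen on a saturated carbon, so that 2-hydroxy-2-methylpropyl becomes 2-methoxy-2-methylpropyl. Among the compounds with values here, one measured step bears on this, the same exchange on a different chain (a 1.9-fold higher number from compound 1 to compound 3 (0.29 log units; within the scatter)), and it lies within the scatter. Within the data shown here, no measurement yet shows the exchange on the 2-hydroxy-2-methylpropyl chain itself. In this assay a small rise in the number is therefore expected, with no step beyond the scatter. The estimate amounts to an expected 1.4-fold higher number from compound 2 to compound 4 (0.15 log units; within the scatter) and so stays within the scatter. For compound 4 the estimated value is 3800 nM (estimated range 1900 nM to 7500 nM).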

Compound 4, half-maximal inhibitory concentration: 5500 nM
The estimate for compound 4 lay 1.4-fold (0.16 log units) below the measured number; the range from low to high includes it.
By their numbers in this assay, from the lowest: compounds 1, 2, 3 and 4 (each within the scatter of the next, the first and the last beyond it).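

In this assay, methyl in place of hydrogen on the oxygen of the 2-hydroxy-2-methylpropyl chain gives a 2.0-fold higher number from compound 2 to compound 4 (0.31 log units; beyond the scatter), so the exchange now has a step of its own on this chain, and that step lies just beyond the scatter. Read with the earlier step on the other chain, the exchange raises the number on both cores by nearly the same size: the same change on two cores in this assay, a 1.9-fold higher number (0.29 log units; within the scatter) from compound 1 to compound 3 and a 2.0-fold higher number (0.31 log units; beyond the scatter) from compound 2 to compound 4, 1.1-fold (0.02 log units) apart, within the scatter of two such steps. Within the data shown here, this agreement rests on two pairs only, and only the step on the 2-hydroxy-2-methylpropyl chain passes the scatter, so the effect remains modest.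

The compounds shown leave open what an ethyl group on this oxygen, or an amine in place of the hydroxy, would do to the number. They also leave open whether the exchange gives a step of similar size on a longer chain.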